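The compounds below may be only part of what the source reports. "The series", "measured", "known", "first", "only" and "open" are said of these compounds alone.

Four compounds on a shared core are compared here. In a functional assay on A549 cells (Homo sapiens) for antiproliferative activity, read by MTT assay, with a stated time of 72 h (a lower number here means a stronger inhibitor, a higher number a weaker inhibitor), compound 1 `O=C(N/N=C/c1ccc(Br)cc1)Nc1ccc(Oc2ccnc3[nH]ccc23)c(F)c1` gives 820 nM and compound 3 `COc1ccc(/C=N/NC(=O)Nc2ccc(Oc3ccnc4[nH]ccc34)c(F)c2)cc1` gives 3980 nM as its result, while compound 2 `O=C(N/N=C/c1cccc(Cl)c1Cl)Nc1ccc(Oc2ccnc3[nH]ccc23)c(F)c1` is reported as "not active" (no number reported) in place of a figure. Compound 3 therefore has the higher of the two numbers, and compound 2 cannot be ranked against them.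

Compound 4 `O=C(N/N=C/c1cc(Br)c(O)c(Br)c1)Nc1ccc(Oc2ccnc3[nH]ccc23)c(F)c1` has not been measured yet. It carries 3,5-dibromo-4-hydroxyphenyl in place of 4-methoxyphenyl on a carbon with a double bond to nitrogen and so loses the methoxy group and gains bromine.

Going by the values given here, one measured step bears on this directly. Methoxy in place of bromo on an aromatic carbon gave a 4.9-fold higher number from compound 1 to compound 3 (0.69 log units; beyond the scatter) as a modest change, and read backwards it points to a lower number when bromine replaces methoxy. Caution is needed, though. Among the compounds with values here, compound 2 also has two halogens on its ring and is reported as "not active" (no number reported) with no figure, and no measured compound carries a hydroxy group. A somewhat smaller downward step in this assay is therefore expected, with wide uncertainty.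

The estimate amounts to an expected 2.7-fold lower number from compound 3 to compound 4 (0.42 log units; beyond the scatter) for this change. Compound 4 is estimated at 1500 nM with an expected range of 400 nM to 6000 nM in this measurement.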

Compound 4, half-maximal inhibitory concentration: 16200 nM
Compound 4: middle estimate off by 11-fold (1.03 log units), on the low side; the measured number lies above the stated range.
By their numbers in this assay, from the lowest: compound 1; then compound 3; then compound 4.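

In this assay, 3,5-dibromo-4-hydroxyphenyl on the carbon with a double bond to nitrogen gives a 4.1-fold higher number from compound 3 to compound 4 (0.61 log units; beyond the scatter), and set against 4-bromophenyl at the same place it gives a 20-fold higher number from compound 1 to compound 4 (1.30 log units; beyond the scatter). Bromine on this ring therefore does not bring a low number by itself: compound 1, with 4-bromophenyl, has the lowest number of the three compounds with figures, while compound 4, with its dibromo group, has the highest, and compound 2 has no figure and cannot be placed in this order. No measurement is available to explain why this group raises the number.

The hydroxy group and the bromines arrive together in compound 4, so the compounds shown cannot tell how much of the rise belongs to each, and a phenyl ring carrying only a hydroxy group would be needed to begin separating them. Also open, going by these compounds, is how this place would respond to a group of another kind on the ring, such as an amine or a carboxylic acid.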